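Methyl on the benzyl ring: an expected small step

The compounds below may be only part of what the source reports. "The series", "measured", "known", "first", "only" and "open" are said of these compounds alone.

Three compounds share one core, and compound 1 `COc1cccc(OC)c1OCCNCCOc1ccccc1OCc1ccccc1` is the starting point. In an assay on CHO cells for displacement of a labelled ligand from Alpha-1B adrenergic receptor (Homo sapiens) (on this read-out higher numbers stand for weaker inhibition and lower numbers for stronger inhibition), compound 1 gives 0.537 nM. Compound 2 `COc1cccc(OC)c1OCCNCCOc1ccccc1OCc1ccccc1Cl` carries a chlorine on the benzyl ring and gives 0.562 nM in this assay; compound 3 `COc1cccc(OC)c1OCCNCCOc1ccccc1OCc1ccc(Cl)cc1` carries a chlorine at another position of the same ring and gives 1 nM. The moves were a 1.0-fold higher number from compound 1 to compound 2 (0.02 log units; within the scatter) and a 1.9-fold higher number from compound 1 to compound 3 (0.27 log units; within the scatter), so all three numbers sit inside the usual scatter of one another, and nothing separates compound 1 from the other two.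

Compound 4 `COc1cccc(OC)c1OCCNCCOc1ccccc1OCc1cccc(C)c1` has not yet been measured. It differs from compound 1 by methyl in place of hydrogen on an aromatic carbon, a small group added on the benzyl ring, meta to a large group. The two measured steps that speak to it are the two halogen additions to the same ring, a 1.0-fold higher number from compound 1 to compound 2 (0.02 log units; within the scatter) and a 1.9-fold higher number from compound 1 to compound 3 (0.27 log units; within the scatter), neither of which left the scatter. A methyl is another small, uncharged group at this ring, so the expectation is a step in this assay of no clear direction and not beyond the scatter.

The estimate for compound 4 is therefore 0.7 nM in this assay, with a range from 0.35 nM to 1.4 nM, expected as a 1.3-fold higher number from compound 1 to compound 4 (0.12 log units; within the scatter).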

Compound 4, inhibition constant: 0.251 nM
Estimate against measurement, compound 4: 2.8-fold (0.45 log units) above, and the stated range ends above it.
By their numbers in this assay, from the lowest: compound 4; then compounds 1, 2 and 3 (each within the scatter of the next).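

Among the compounds shown here, the methyl is the first change on this benzyl ring to leave the scatter in this assay: it gives a 2.1-fold lower number from compound 1 to compound 4 (0.33 log units; beyond the scatter) and moves towards stronger inhibition, although the step is modest. It also sets compound 4 apart from both chlorinated compounds, with a 2.2-fold lower number from compound 2 to compound 4 (0.35 log units; beyond the scatter) and a 4.0-fold lower number from compound 3 to compound 4 (0.60 log units; beyond the scatter) on the same read-out, so compound 4 is the strongest inhibitor of the four, and a small change on this ring can shift the number measurably. Nothing shown here gives a reason for this shift.

The two steps from the chlorinated compounds change both the group and its place on the ring, so they cannot show which of the two matters; a chlorine on the same aromatic carbon as the methyl would separate them. As far as these compounds go, it also remains open whether an ethyl, a methoxy or an amine on that carbon would move the number further in the same direction, or back towards compound 1.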